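Solubility notes: compound 4 as a dimethylpiperidine analogue

The compounds below may be only part of what the source reports. "The series", "measured", "known", "first", "only" and "open" are said of these compounds alone.

Measured in a physicochemical assay for solubility, in the presence of a further agent that is not named here; a lower number here means a less soluble compound, a higher number a more soluble compound:
compound 1 `[O-][n+]1nc(NCCN2CCCCC2)[n+]([O-])c2ccccc21` gives > 49000000 nM, which is a limit of the assay and not a number.
compound 2 `COc1ccc2c(c1)[n+]([O-])c(NCCN(C)C)n[n+]2[O-]` gives 46000000 nM.
compound 3 `COc1ccc2c(c1)[n+]([O-])c(NCCN1CCCCC1)n[n+]2[O-]` gives 45000000 nM.

Compound 3 and compound 2 sit within the scatter of each other: a 1.0-fold lower number from compound 2 to compound 3 (0.01 log units; within the scatter). The other step, an at least 1.0-fold lower number from compound 1 to compound 3 (0.03 log units; that floor lies within the scatter), has its floor set by the limit of > 49000000 nM in this assay, at which 1 of the 3 values shown sits. Compound 4 `COc1ccc2c(c1)[n+]([O-])c(NCCN1C(C)CCCC1C)n[n+]2[O-]` differs from compound 3 by 2,6-dimethylpiperidin-1-yl in place of piperidin-1-yl on a saturated chain carbon, two bonds along the chain from a nitrogen on an aromatic ring. For the measured compounds named here, only one measured step touches the same position, and it stayed within the scatter; nothing measured covers the two methyl groups themselves. The expected step in this assay is therefore a 1.3-fold lower number from compound 3 to compound 4 (0.11 log units; within the scatter), not clearly beyond the scatter. Compound 4 is estimated at 35000000 nM, with a range from 12000000 nM to 50000000 nM.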

Compound 4, solubility: 29000000 nM
Compound 4: middle estimate off by 1.2-fold (0.08 log units), on the high side; the measured number falls inside the stated range.
By their numbers in this assay, from the lowest: compounds 4, 3 and 2 (each within the scatter of the next). At a limit, above all of these: compound 1.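

In this assay, the place on a saturated chain carbon, two bonds along the chain from a nitrogen on an aromatic ring, now also carries 2,6-dimethylpiperidin-1-yl, and both new steps stay within the scatter (a 1.6-fold lower number from compound 3 to compound 4 (0.19 log units; within the scatter); a 1.6-fold lower number from compound 2 to compound 4 (0.20 log units; within the scatter)). For the compounds shown here, the two added methyl groups therefore give no step that can be told from the scatter, so this place is still without a clear difference. No measurement shown bears on the size of these steps.

Going by these compounds, whether a morpholine ring or a carboxylic acid at this place would stay within the scatter remains open. So does the outcome of a longer chain between the shared core and the amine.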